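This account rests on a few compounds, and the source may have more. Where it says the series, first, only, none or still open, it means among the compounds named here.

Compound 1 `COc1cc2c(Nc3nc4ccc(C(=O)Nc5c(C)cccc5C)cc4s3)ncnc2cc1OCCCN1CCCC1` and compound 2 `COc1cc2c(Nc3nc4ccc(C(=O)Nc5c(C)cccc5C)cc4s3)ncnc2cc1OCCCN1CCCCC1` share one core; compound 3 `COc1cc2c(Nc3nc4ccc(C(=O)Nc5c(C)cccc5Cl)cc4s3)ncnc2cc1OCCCN1CCCC1` and the still unmeasured compound 4 `COc1cc2c(Nc3nc4ccc(C(=O)Nc5c(C)cccc5Cl)cc4s3)ncnc2cc1OCCCN1CCCCC1` differ from them as chloro in place of methyl on an aromatic carbon shows. In a functional assay on HCT-116 cells (Homo sapiens) for cytotoxicity, read by WST assay, with a stated time of 72 h (on this read-out lower numbers stand for stronger inhibition and higher numbers for weaker inhibition), compound 1 gives only a limit of the assay, > 100000 nM. Compound 2 likewise gives a limit, > 100000 nM. Compound 3 gives 63800 nM, so there is an at least 1.5-fold lower number from compound 1 to compound 3 (0.19 log units; that floor lies within the scatter). Between compound 1 and compound 2 the change is piperidin-1-yl in place of pyrrolidin-1-yl on a saturated chain carbon, three bonds along the chain from an oxygen on an aromatic ring, and the step is a step that the two limits leave unreadable from compound 1 to compound 2 because of the limit of > 100000 nM in this assay, at which 2 of the 3 values shown sit. Compound 4 arises from compound 3 by the same change, (piperidin-1-yl in place of pyrrolidin-1-yl on a saturated chain carbon, three bonds along the chain from an oxygen on an aromatic ring). For compound 4 a step of a 1.1-fold higher number from compound 3 to compound 4 (0.04 log units; within the scatter) in this assay is expected, resting on compound 1 and compound 2 both sitting at the limit of > 100000 nM in this assay, at which 2 of the 3 values shown sit, after this change. Compound 4 is therefore estimated at 70000 nM, between 25000 nM and 200000 nM.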

Compound 4, half-maximal inhibitory concentration: 23400 nM
Compound 4: the middle estimate sits 3.0-fold (0.48 log units) above what was measured; the whole stated range lies above it.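

Carried onto the core with piperidin-1-yl, chloro in place of methyl gives an at least 4.2-fold lower number from compound 2 to compound 4 (0.63 log units; beyond the scatter) in this assay. Whether this change does as much on the core with pyrrolidin-1-yl stays undecided: the same change on two cores in this assay, an at least 1.5-fold lower number (0.19 log units; that floor lies within the scatter) from compound 1 to compound 3 and an at least 4.2-fold lower number (0.63 log units; beyond the scatter) from compound 2 to compound 4; the limit leaves it open whether they differ Piperidin-1-yl in place of pyrrolidin-1-yl gives a 2.7-fold lower number from compound 3 to compound 4 (0.44 log units; beyond the scatter), but the same swap on the methyl-bearing core cannot be read, so these compounds do not show that this step carries from one core to the other: the limit of > 100000 nM in this assay, at which 2 of the 4 values shown sit.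

The compounds shown leave open whether fluoro or methoxy in place of the chloro would lower the number further. They also leave open what a morpholin-4-yl group or a longer chain would do.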